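The compounds below may be only part of what the source reports. "The series", "measured", "known", "first", "only" and "open" are said of these compounds alone.

Measured compounds:
compound 1 `CC(C)C(c1ccc(-c2ccc3cccc(F)c3c2)[nH]c1=O)N1CCCCS1(=O)=O` — 122 nM
compound 2 `Cc1nc(C(c2ccc(-c3ccc4cccc(F)c4c3)[nH]c2=O)C(C)C)[nH]c1C` — 50 nM
compound 3 `CC(C)C(c1nnc[nH]1)c1ccc(-c2ccc3cccc(F)c3c2)[nH]c1=O` — 21 nM

In a functional assay on CHO cells for antagonist activity at prostaglandin E2 receptor EP3 subtype (Homo sapiens), read by cAMP accumulation (on this read-out higher numbers stand for weaker inhibition and lower numbers for stronger inhibition), compound 1 gives the highest number of the three. Its nearest neighbour is compound 2, reached by a 2.4-fold lower number from compound 1 to compound 2 (0.39 log units; beyond the scatter), and the furthest is compound 3, reached by a 5.8-fold lower number from compound 1 to compound 3 (0.76 log units; beyond the scatter). Between those two azoles the step is a 2.4-fold lower number from compound 2 to compound 3 (0.38 log units; beyond the scatter).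

Compound 4 `CC(C)C(c1ncc[nH]1)c1ccc(-c2ccc3cccc(F)c3c2)[nH]c1=O` is not yet measured. It differs from compound 1 in one place: a group of 5 heavy atoms (3 carbon, 2 nitrogen; one five-membered aromatic ring with 2 hetero atoms) in place of a group of 8 heavy atoms (4 carbon, 1 nitrogen, 2 oxygen, 1 sulfur; one six-membered non-aromatic ring with 2 hetero atoms), on a saturated chain carbon bound to an aromatic carbon and a saturated chain carbon.

Both measured steps from compound 1 bear on this change, since each puts a five-membered aromatic ring with two or three hetero atoms on the same saturated chain carbon in place of the six-membered non-aromatic ring. Both lower the number beyond the scatter, and the smaller ring with more nitrogen atoms gives the lower number. The group entering compound 4 sits between those two in size and nitrogen count, so a modest step down in this assay is expected, of roughly a 3.8-fold lower number from compound 1 to compound 4 (0.58 log units; beyond the scatter).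

Compound 4 is therefore estimated at 32 nM, with a range of 12 nM to 80 nM.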

Compound 4, half-maximal inhibitory concentration: 33 nM
Compound 4: the middle estimate sits 1.0-fold (0.01 log units) below what was measured, within the range that was stated.
By their numbers in this assay, from the lowest: compounds 3, 4 and 2 (each within the scatter of the next, the first and the last beyond it); then compound 1.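

Replacing the six-membered ring on this saturated chain carbon with the plain 1H-imidazol-2-yl group still lowers the number in this assay (with a 3.7-fold lower number from compound 1 to compound 4 (0.57 log units; beyond the scatter)), so this step needs neither the 4,5-dimethyl groups of compound 2 nor the 4H-1,2,4-triazol-3-yl ring of compound 3. Compound 4 cannot be separated from either of the other azoles (with a 1.6-fold higher number from compound 3 to compound 4 (0.20 log units; within the scatter) and a 1.5-fold lower number from compound 2 to compound 4 (0.18 log units; within the scatter)). The gap between compound 2 and compound 3 remains beyond the scatter (with a 2.4-fold lower number from compound 2 to compound 3 (0.38 log units; beyond the scatter)), but compound 4 does not assign that gap to the ring nitrogen or to the 4,5-dimethyl groups.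

No measurement shown accounts for these steps. Also open, on these data alone, is whether a carboxylic acid or a primary amine on this saturated chain carbon would match the azoles in this assay.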